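Adding a Second Chloro Group: What to Expect

The source may hold more compounds than are shown below. What is called first, only, known or untested is meant among the compounds shown, and "the series" means these compounds.

Of the compounds shown here, three that share one core have been tested in a functional assay on NCI-H226 cells (Homo sapiens) for inhibition, read by sulforhodamine B assay, with a stated time of 48 h; on this read-out lower numbers stand for stronger inhibition of growth and higher numbers for weaker inhibition of growth. Compound 1 `COc1cc(C(=O)N2CCN(C=O)C2=S)cc(OC)c1OC` gives 35900 nM. Compound 2 `O=CN1CCN(C(=O)c2ccco2)C1=S` gives 28500 nM. Compound 3 `O=CN1CCN(c2ccc(Cl)cc2)C1=S` gives 43400 nM. Compound 3 is the one that carries an aromatic ring with a chloro group attached directly to the core. Its number lies within the usual scatter of both other numbers, so none of the three can be set apart from the others: on this evidence all three are weak inhibitors of growth of about the same strength.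

Compound 4 `O=CN1CCN(c2ccc(Cl)c(Cl)c2)C1=S` differs from compound 3 in a single place: chloro in place of hydrogen on an aromatic carbon. Within the data shown here, no pair of measured compounds shows what this particular change does, so any expectation can rest only on the narrow spread seen so far. Among the measured compounds shown here, with the three measured numbers sitting close together and no measured step to lean on, a step from compound 3 to compound 4 of a 1.4-fold lower number from compound 3 to compound 4 (0.16 log units; within the scatter) is expected, leaning towards somewhat stronger inhibition of growth if anything, but not clearly beyond the scatter. Compound 4 is therefore estimated at 30000 nM, with a range from 10000 nM to 90000 nM.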

Compound 4, concentration for 50% growth inhibition: 20700 nM
The estimate for compound 4 lay 1.4-fold (0.16 log units) above the measured number, and the stated range covers the measured number.
By their numbers in this assay, from the lowest: compounds 4, 2, 1 and 3 (each within the scatter of the next, the first and the last beyond it).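

In this assay, among these compounds, adding a second chloro group to the aromatic ring gives the first step that can be read beyond the usual scatter: a 2.1-fold lower number from compound 3 to compound 4 (0.32 log units; beyond the scatter). The step is modest, but it shows that at this position, ortho to a chloro group and meta to a group of 8 heavy atoms, chloro in place of hydrogen goes with stronger inhibition of growth, something the three earlier compounds, whose numbers could not be told apart, had no way of showing. No measurement shown here bears on the reason for this step.

The compounds shown leave open whether a different group in the same place, such as a fluoro group, a methoxy group or an amine, would move the number in the same direction or by a similar amount. They also leave open whether this gain depends on the chloro group already on the ring, since this single step shows the new chloro group only alongside that first one.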